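Removing a Methyl from a Pyridine Thiosemicarbazide

The source may hold more compounds than are shown below. What is called first, only, known or untested is meant among the compounds shown, and "the series" means these compounds.

Measured so far:
compound 1 `Cc1cccc(/C(N)=N/NC(=S)N2CCCC2)n1` gives 2700 nM
compound 2 `Cc1ccnc(/C(N)=N/NC(=S)N2CCN(c3ccccn3)CC2)c1` gives 10500 nM

Of the compounds shown here, two have been tested in a functional assay on HeLa cells (Homo sapiens) for cytotoxicity, read by MTT assay, with a stated time of 72 h; a lower number here means a stronger inhibitor, a higher number a weaker inhibitor. Compound 1 gives 2700 nM, while compound 2 gives 10500 nM, the higher of the two numbers; the gap between them lies beyond the scatter, so compound 2 is the weaker of the pair.

Compound 3 `N/C(=N\NC(=S)N1CCN(c2ccccn2)CC1)c1ccccn1` is the next to be measured. It differs from compound 2 in one place: hydrogen in place of methyl on an aromatic carbon. Read one bond further out, the change is 4-methylpyridin-2-yl to pyridin-2-yl. Going by the values given here, no measured pair shows this same change, so there is no step to lean on. A change of a single heavy atom is expected to shift the number in this assay only slightly, most likely within the scatter, with no preferred direction. Compound 3 is therefore estimated at 9000 nM, with a range from 3500 nM to 25000 nM. The expected step is a 1.2-fold lower number from compound 2 to compound 3 (0.07 log units; within the scatter), not beyond the scatter.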

Compound 3, half-maximal inhibitory concentration: 8600 nM
For compound 3 the middle estimate is 1.0-fold (0.02 log units) above the measured one; the range from low to high includes it.
By their numbers in this assay, from the lowest: compound 1; then compounds 3 and 2 (each within the scatter of the next).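

In this assay, going from 4-methylpyridin-2-yl to pyridin-2-yl gives a 1.2-fold lower number from compound 2 to compound 3 (0.09 log units; within the scatter), so removing this methyl, on an aromatic carbon opposite the ring nitrogen, leaves a difference that cannot be told apart from ordinary repeat-to-repeat variation. Going by these compounds alone, this is the first direct look at this position, since compound 1 and compound 2 differ in more than one place and could not isolate the methyl; this pair shows that, in this test and on this core, the methyl can be swapped for hydrogen without a step beyond the scatter. No measurement at hand offers a reason for this outcome.

From the compounds shown here alone, the pair covers only methyl and hydrogen at this position, so it remains open whether an amine, a methoxy group, a chlorine atom or a longer chain such as ethyl would give a number close to these or a clearly different one. Within the data shown here, it also remains open which of the several differences sets compound 1 apart from compound 2, as no single-place step connects them.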